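This account rests on a few compounds, and the source may have more. Where it says the series, first, only, none or still open, it means among the compounds named here.

Measured in a functional assay on the whole organism with Mus musculus as the target; a lower number here means that less compound is needed, a higher number that more compound is needed for the effect:
- compound 1 `CN(C)C(=O)/C=C1\CCc2ccc(F)cc21`: > 100 mg/kg (a limit of the assay, not a number)
- compound 2 `CCN(C)C(=O)/C=C1\CCc2c(F)cc(F)cc21`: 56 mg/kg
- compound 3 `CC(C)NC(=O)/C=C1\CCc2ccc(F)cc21`: 96 mg/kg

Compound 3 and compound 2 lie within the scatter of each other. The entry for compound 1 is a limit. Not yet measured is compound 4 `CCN(C)C(=O)/C=C1\CCc2ccc(F)cc21`, with ethyl(methyl)amino in place of isopropylamino on a carbonyl carbon. Within the data shown here, one measured step bears on this change, an at least 1.0-fold lower number from compound 1 to compound 3 (0.01 log units; that floor lies within the scatter), and it starts from the limit of > 100 mg/kg in this assay, at which 1 of the 3 values shown sits. Among the measured compounds shown here, with only that step from compound 1 as a guide, no change beyond the scatter is expected in this assay. The expected step is a 1.1-fold lower number from compound 3 to compound 4 (0.05 log units; within the scatter). For compound 4 the estimate is 85 mg/kg, with an expected range of 45 mg/kg to 160 mg/kg.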

Compound 4, dose for half-maximal effect: 100 mg/kg
Compound 4: middle estimate off by 1.2-fold (0.07 log units), on the low side; low and high end bracket the measured number.
By their numbers in this assay, from the lowest: compounds 2, 3 and 4 (each within the scatter of the next).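

In this assay, ethyl(methyl)amino in place of isopropylamino on a carbonyl carbon gives a 1.0-fold higher number from compound 3 to compound 4 (0.02 log units; within the scatter), so going from 1 hydrogen-bond donor to 0 in this group shows no change beyond the scatter here. Hydrogen in place of fluoro on an aromatic carbon gives a 1.8-fold higher number from compound 2 to compound 4 (0.25 log units; within the scatter), so that change shows none either. Methyl in place of hydrogen on a saturated chain carbon bound to an amide-type nitrogen gives a number no higher from compound 1 to compound 4 (the limit leaves the size open). This step cannot be read, because compound 1 stands at a limit: the limit of > 100 mg/kg in this assay, at which 1 of the 4 values shown sits.

Open, from the compounds shown here alone, is whether a longer chain such as hexyl or a piperidine amide in place of these amino groups moves the number beyond the scatter. Also open, going by these compounds, is whether chloro or methoxy on an aromatic carbon does so.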